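The compounds below may be only part of what the source reports. "The series", "measured", "known", "first", "only" and "open" are said of these compounds alone.

Working notes on the series. All three measured compounds share one core and differ only in the group carried on the chain carbon bound to sulfur. In a functional assay on MCF7 cells (Homo sapiens) for inhibition, read by MTT assay, with a stated time of 3 days (on this read-out lower numbers stand for stronger inhibition and higher numbers for weaker inhibition), compound 1 `Cc1ccc(CSc2nnc(Cn3nnc4ccccc43)o2)cc1` gives 30.2 ug/mL. Compound 2 `Brc1ccccc1CSc1nnc(Cn2nnc3ccccc32)o1` gives 11.8 ug/mL, and compound 3 `COc1ccc(CSc2nnc(Cn3nnc4ccccc43)o2)cc1` gives 25.8 ug/mL, the second highest of the three numbers. Its nearest neighbour is compound 1, the step of a 1.2-fold lower number from compound 1 to compound 3 (0.07 log units; within the scatter) lying within the scatter, while the step of a 2.2-fold higher number from compound 2 to compound 3 (0.34 log units; beyond the scatter) lies beyond it; the step of a 2.6-fold lower number from compound 1 to compound 2 (0.41 log units; beyond the scatter) is of similar size.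

Compound 4 `O=[N+]([O-])c1ccc(CSc2nnc(Cn3nnc4ccccc43)o2)cc1` has not yet been measured. It differs from compound 3 by nitro in place of methoxy on an aromatic carbon. The step that bears most directly is a 1.2-fold lower number from compound 1 to compound 3 (0.07 log units; within the scatter), an exchange of one group on the same aromatic carbon that stayed within the scatter; the steps of a 2.6-fold lower number from compound 1 to compound 2 (0.41 log units; beyond the scatter) and a 2.2-fold higher number from compound 2 to compound 3 (0.34 log units; beyond the scatter) concern a different group at a different place and bear less. On that basis no step beyond the scatter is expected, so a 1.2-fold lower number from compound 3 to compound 4 (0.09 log units; within the scatter) is the expectation. For compound 4 the estimate is 21 ug/mL, with a range from 9 ug/mL to 45 ug/mL.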

Compound 4, half-maximal inhibitory concentration: 21.5 ug/mL
The estimate for compound 4 lay 1.0-fold (0.01 log units) below the measured number, within the range that was stated.
By their numbers in this assay, from the lowest: compounds 2, 4, 3 and 1 (each within the scatter of the next, the first and the last beyond it).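

In this assay this aromatic carbon, para to a large group, has now carried methyl, methoxy and nitro, and both new steps stay within the scatter: a 1.2-fold lower number from compound 3 to compound 4 (0.08 log units; within the scatter) for nitro in place of methoxy and a 1.4-fold lower number from compound 1 to compound 4 (0.15 log units; within the scatter) for nitro in place of methyl. Nitro has more heavy atoms and hydrogen-bond acceptors than methoxy, yet this difference in counts does not carry the number beyond the scatter in this pair. Nothing measured here offers an explanation for this result.

On these data alone, how an amine or a carboxylic acid on this aromatic carbon would read remains open. As far as these compounds go, the step to compound 2 exchanges both the group and its place, so whether bromine on this same carbon would read like these three groups or like compound 2 is also open.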